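Halogen swaps on the phenoxy ring of the coumarin series

The source may report more compounds than this note shows. Statements on the series, on what has been measured and on what is new or still open speak of the compounds shown alone.

Measured compounds:
compound 1 `Cc1nn(C)c(Oc2cccc(F)c2)c1/C=N\CCCCCOc1cc2oc(=O)cc(C)c2cc1Cl` — in a functional assay on HepG2 cells (Homo sapiens) for antiproliferative activity, read by MTT assay, with a stated time of 72 h (on this read-out higher numbers stand for weaker inhibition and lower numbers for stronger inhibition), compound 1 gives 13400 nM
compound 2 `Cc1nn(C)c(Oc2ccc(Br)cc2)c1/C=N\CCCCCOc1cc2oc(=O)cc(C)c2cc1Cl` — in this assay compound 2 gives 13800 nM

Going by the values given here, compound 2 and compound 1 sit within the scatter of each other; the only measured step, a 1.0-fold higher number from compound 1 to compound 2 (0.01 log units; within the scatter), did not move the number. Compound 3 `Cc1nn(C)c(Oc2ccc(I)cc2)c1/C=N\CCCCCOc1cc2oc(=O)cc(C)c2cc1Cl` carries the change (iodo in place of bromo on an aromatic carbon). Among the compounds with values here, the one step that bears on it exchanged halogens on the same ring without effect, so no step beyond the scatter is expected in this assay, giving an expected 1.0-fold lower number from compound 2 to compound 3 (0.01 log units; within the scatter). Compound 3 is therefore estimated at 13500 nM, with a range of 6800 nM to 27000 nM.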

Compound 3, half-maximal inhibitory concentration: > 25000 nM
Compound 3 was reported as a limit; the forecaster's own chance of this, stated with the estimate: 5%; middle value at least 1.8-fold (0.26 log units) from the limit.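

In this assay compound 3 is reported only as a limit, > 25000 nM, not as a number: the limit of > 25000 nM in this assay, at which 1 of the 3 values shown sits. The iodo exchange reads an at least 1.8-fold higher number from compound 2 to compound 3 (0.25 log units; that floor lies within the scatter), and the change from the 3-fluorophenyl group reads an at least 1.8-fold higher number from compound 1 to compound 3 (0.27 log units; that floor lies within the scatter). Unlike the earlier halogen swap, these steps carry only a floor, so this position may or may not separate iodo from bromo.

Where the number for compound 3 actually lies stays open. Also open, going by these compounds, is how an amine or a carboxylic acid on this aromatic carbon would read against the halogens.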